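Cytotoxicity notes on the isoxazole ester series

A few compounds are considered here, and "the series" means these few. Any claim that something is new, unique, unknown or untested is made for them only; others in the source may bear on it.

Measured in an ADME assay on Vero cells (Chlorocebus sabaeus) for cytotoxicity, with a stated time of 72 h; on this read-out higher numbers stand for weaker inhibition and lower numbers for stronger inhibition:
- compound 1 `CCOC(=O)c1cc(-c2cccc(OCc3cccc(N)c3)c2)on1`: > 128000 nM
- compound 2 `CCOC(=O)c1cc(-c2cccc(OCc3cccc(OC)c3)c2)on1`: > 128000 nM

Both values are limits of this assay, not numbers. Compound 1 stands at the limit of > 128000 nM. Compound 2 also sits at the limit of > 128000 nM. Within the data shown here, the one measured step, a step that the two limits leave unreadable from compound 1 to compound 2, is therefore unreadable, and the limit of > 128000 nM in this assay, at which 2 of the 2 values shown sit, is all the evidence the pair gives.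

Compound 3 `CCOC(=O)c1cc(-c2cccc(OCc3ccc(F)c(F)c3F)c2)on1` is not yet measured. It differs from compound 1 by 2,3,4-trifluorophenyl in place of 3-aminophenyl on a saturated chain carbon bound to an oxygen on an aromatic ring. Among the measured compounds shown here, no measured step bears directly on this change; the only step in hand is a step that the two limits leave unreadable from compound 1 to compound 2, which gives no size. With compound 1 at its limit of > 128000 nM, the expectation is that compound 3 likewise returns a limit, with an estimated step of a number no higher from compound 1 to compound 3 (the limit leaves the size open). The estimate for compound 3 is 128000 nM, in the range 40000 nM to 400000 nM.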

Compound 3, half-maximal inhibitory concentration: > 128000 nM
Compound 3: no number, only a limit (the forecaster's own chance of this, stated with the estimate: 85%); the middle value lies on the limit itself.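

In this assay compound 3 gives > 128000 nM, a limit and not a number, so the steps to compound 3 from compound 1 and compound 2 cannot be read. The compounds shown leave open whether any of them truly differs from the others on this read-out: the limit of > 128000 nM in this assay, at which 3 of the 3 values shown sit.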